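The source may hold more compounds than are shown below. What is called first, only, known or untested is meant among the compounds shown, and "the series" means these compounds.

In a functional assay on A549 cells (Homo sapiens) for cytotoxicity, read by MTT assay, with a stated time of 48 h (on this read-out lower numbers stand for stronger inhibition and higher numbers for weaker inhibition), compound 1 (`COc1cc(-c2cc(COCc3cn(Cc4cc(-c5ccc(C)cc5)cnc4Cl)nn3)on2)cc(OC)c1OC`) gives 30600 nM, compound 2 (`COc1cc(C2CC(COCc3cn(Cc4cc(-c5ccc(F)cc5)cnc4Cl)nn3)ON2C=O)cc(OC)c1OC`) gives 25200 nM and compound 3 (`COc1cc(C2=NOC(COCc3cn(Cc4cc(C)cnc4Cl)nn3)C2)cc(OC)c1OC`) gives 37700 nM. These numbers lie within the usual scatter of one another, so compound 3 stands level with the other two. Compound 4 (`COc1cc(C2=NOC(COCc3cn(Cc4cc(-c5ccccc5)cnc4Cl)nn3)C2)cc(OC)c1OC`) has phenyl in place of methyl on an aromatic carbon. Among the compounds with values here, no measured pair shows this change alone. Compound 1 also carries a ring at that place, though it differs elsewhere too, and its 30600 nM is level with compound 3 at 37700 nM. In this assay, no step beyond the scatter is therefore expected, and the estimated step is a 1.3-fold lower number from compound 3 to compound 4 (0.10 log units; within the scatter). Compound 4 is estimated at 30000 nM, within an expected range of 15000 nM to 60000 nM.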

Compound 4, half-maximal inhibitory concentration: 8600 nM
The estimate for compound 4 lay 3.5-fold (0.54 log units) above the measured number; measured number outside the range, below it.
By their numbers in this assay, from the lowest: compound 4; then compounds 2, 1 and 3 (each within the scatter of the next).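

In this assay, placing phenyl instead of methyl on the aromatic carbon para to a chloro group gives a 4.4-fold lower number from compound 3 to compound 4 (0.64 log units; beyond the scatter), so the group at this position can change the read-out. The earlier compounds shown here could not show this, since none formed a pair differing in one place. No measurement here explains the step. The compounds shown leave open whether an aromatic ring is needed at this position, or whether a cyclohexyl ring or a longer chain such as butyl would serve equally. On these data alone, an amine on the phenyl ring also remains untested here.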